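The compounds below may be only part of what the source reports. "The series", "measured", "known", "first", "only" and "open" are said of these compounds alone.

Measured in a functional assay on DU-145 cells (Homo sapiens) for inhibition, read by trypan blue exclusion, with a stated time of 96 h; on this read-out higher numbers stand for weaker inhibition of growth and lower numbers for stronger inhibition of growth:
- compound 1 `O=C(/C(=C\c1ccc([N+](=O)[O-])c(O)c1)SCc1ccc(Br)cc1)c1ccc(C(F)(F)F)cc1`: 1000 nM
- compound 2 `O=C(/C(=C\c1cc(I)c(O)c(I)c1)SCc1ccc(Br)cc1)c1ccc(Br)cc1`: 1000 nM

In this assay, compound 2 gives 1000 nM, which is level with compound 1 within the usual scatter. Among the compounds with values here, these are the only two measurements so far, and they do not differ in a single place, so no measured single-change step is available as a guide.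

Compound 3 `O=C(/C(=C\c1ccc([N+](=O)[O-])c(O)c1)SCc1ccc(Br)cc1)c1ccc(Br)cc1` is the next to be tested. It is made from compound 2 by placing 3-hydroxy-4-nitrophenyl in place of 4-hydroxy-3,5-diiodophenyl on a double-bonded chain carbon bound to a double-bonded chain carbon. The incoming group is already present in compound 1, which gives 1000 nM. The outgoing group belongs to compound 2, which gives 1000 nM. With both groups found at the same level, no change beyond the scatter is expected in this assay, and no direction can be favoured. The expected size of the change is no change at the digits printed from compound 2 to compound 3 (within the scatter). For compound 3 the estimated value is 1000 nM. The expected range for compound 3 runs from 400 nM to 2500 nM.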

Compound 3, concentration for 50% growth inhibition: 10000 nM
Beside the measured number, compound 3's estimate is 10-fold (1.00 log units) below it, outside the stated range (above it).
By their numbers in this assay, from the lowest: compounds 1 and 2 (each within the scatter of the next); then compound 3.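

In this assay, placing 3-hydroxy-4-nitrophenyl in place of 4-hydroxy-3,5-diiodophenyl on a double-bonded chain carbon bound to a double-bonded chain carbon, with the bromo group held fixed on the other aromatic ring, gives a 10-fold higher number from compound 2 to compound 3 (1.00 log units; beyond the scatter), so this position is not indifferent to the change, and the result is weaker inhibition of growth. Holding 3-hydroxy-4-nitrophenyl fixed instead, bromo in place of trifluoromethyl on an aromatic carbon gives a 10-fold higher number from compound 1 to compound 3 (1.00 log units; beyond the scatter), so a small swap at this second place also matters, something compounds 1 and 2 could not show because they differ in two places at once. The data offer no measured property that would account for either step.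

From the compounds shown here alone, the exchanged rings differ in several features at once, so it remains open whether the nitro group, the iodines or the position of the hydroxyl carries the step from compound 2 to compound 3. Also open, going by these compounds, is how an amine in place of the nitro group, or chloro or methoxy in place of bromo on the aromatic carbon, would read in this assay.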